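Chloro for Methyl Across Two Related Cores

This account rests on a few compounds, and the source may have more. Where it says the series, first, only, none or still open, it means among the compounds named here.

Measured compounds:
compound 1, `CCOC(=O)c1c(-c2cc3cc(OC)ccc3oc2=O)nn(-c2cccc(C)c2)c1C(=O)OCC`, 102000 nM
compound 2, `CCOC(=O)c1c(-c2cc3cc(OC)ccc3oc2=O)nn(-c2cccc(Cl)c2)c1C(=O)OCC`, 148000 nM
compound 3, `CCOC(=O)c1c(-c2cc3ccc(OCC=C(C)C)cc3oc2=O)nn(-c2cccc(C)c2)c1C(=O)OCC`, 178000 nM

Of the compounds shown here, three have been measured in a functional assay on A549 cells (Homo sapiens) for cytotoxicity, read by MTT assay, with a stated time of 48 h; a lower number here means a stronger inhibitor, a higher number a weaker inhibitor. Compound 1 gives 102000 nM, and compound 2 gives 148000 nM. The two differ by chloro in place of methyl on an aromatic carbon, and the result is a 1.5-fold higher number from compound 1 to compound 2 (0.16 log units; within the scatter), so the pair shows no change that can be trusted.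

Compound 3 carries a different core from compound 1; how the two cores differ is not broken down here. In this assay compound 3 gives 178000 nM, which sits within the scatter of both compound 1 and compound 2, so no order among the three is claimed.

Compound 4, `CCOC(=O)c1c(-c2cc3ccc(OCC=C(C)C)cc3oc2=O)nn(-c2cccc(Cl)c2)c1C(=O)OCC`, has not yet been measured. It differs from compound 3 by chloro in place of methyl on an aromatic carbon, the same change that separates compound 1 from compound 2, made on the same kind of place. Among the measured compounds shown here, the only guide to its effect is the earlier pair, where the step stayed within the scatter.

The step from compound 3 to compound 4 is therefore expected to be small, a 1.4-fold higher number from compound 3 to compound 4 (0.15 log units; within the scatter), because a 1.5-fold higher number from compound 1 to compound 2 (0.16 log units; within the scatter) gave no more than that on the first core. Compound 4 is estimated at 250000 nM in this assay, with a likely range from 120000 nM to 500000 nM. This rests on one prior pair only; whether the second core behaves the same way remains to be seen.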

Compound 4, half-maximal inhibitory concentration: 163000 nM
For compound 4 the middle estimate is 1.5-fold (0.19 log units) above the measured one, and the stated range covers the measured number.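

In this assay, chloro in place of methyl on the second core gives a 1.1-fold lower number from compound 3 to compound 4 (0.04 log units; within the scatter), so this step, like the earlier one on the first core, shows no change that can be trusted. Set side by side, the two steps do not differ: the same change on two cores in this assay, a 1.5-fold higher number (0.16 log units; within the scatter) from compound 1 to compound 2 and a 1.1-fold lower number (0.04 log units; within the scatter) from compound 3 to compound 4, 1.6-fold (0.20 log units) apart, within the scatter of two such steps This shows that the move from 3-methylphenyl to 3-chlorophenyl stays within the scatter on both cores and that the two cores give no sign of answering it differently, but it does not show that a real effect carries from one core to the other, as neither step can be told apart from no effect at all, and two pairs are a narrow basis for any rule about this series.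

The compounds shown all keep the same two ethyl esters and place only methyl or chloro on the aromatic ring, so it remains open whether a carboxylic acid or an amide in place of an ester would move the number beyond the scatter. Going by these compounds, it is equally open whether an amine or a methoxy group on that ring would do so on either core.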